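The compounds below may be only part of what the source reports. "The series", "measured", "known", "first", "only" and "open" are said of these compounds alone.

Measured so far in a functional assay on Jurkat cells (Homo sapiens) for antiproliferative activity, read by WST assay, with a stated time of 72 h; a lower number here means a stronger inhibitor, a higher number a weaker inhibitor:
compound 1, `Cc1noc(-c2cc3cc(F)ccc3[nH]2)n1`, gives 22900 nM;
compound 2, `Cc1noc(-c2cc3cc(Cl)ccc3[nH]2)n1`, gives 21600 nM.

Among the compounds with values here, compound 1 stands at the higher of the two numbers, but the only measured step, a 1.1-fold lower number from compound 1 to compound 2 (0.03 log units; within the scatter), is within the scatter, so compound 1 and compound 2 cannot be ordered by these numbers.

Compound 3, `Fc1ccc2[nH]c(-c3nc(-c4ccccc4)no3)cc2c1`, is not yet measured. It differs from compound 1 by phenyl in place of methyl on an aromatic carbon. Within the data shown here, the single measured step, chloro for fluoro on the shared core, concerns a different position and a different kind of change; no measured step bears on exchanging the methyl for a phenyl. There is thus no basis in these data for a directed expectation, and the working assumption is a number near that of compound 1 with wide uncertainty on both sides.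

Compound 3 is therefore expected to give about 18000 nM in this assay, estimated to fall between 4000 nM and 70000 nM. The expected step is a 1.3-fold lower number from compound 1 to compound 3 (0.10 log units; within the scatter), which is not beyond the scatter.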

Compound 3, half-maximal inhibitory concentration: 33800 nM
Estimate against measurement, compound 3: 1.9-fold (0.27 log units) below; measured number inside the range.
By their numbers in this assay, from the lowest: compounds 2, 1 and 3 (each within the scatter of the next).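

In this assay, within the data shown here, the first measured change on the carbon between two ring nitrogen atoms gives a 1.5-fold higher number from compound 1 to compound 3 (0.17 log units; within the scatter). Exchanging methyl for phenyl thus adds a six-membered aromatic ring of carbon only at this position without moving the number beyond the scatter, so this change does not separate the two compounds. No other measurement bears on this result.

As far as these compounds go, whether an amine, a carboxylic acid or a longer chain at this position would give a number beyond the scatter remains open, as does the effect of a substituted phenyl. Also open is whether phenyl in place of methyl gives a similar step on the chloro counterpart of the shared core, since the compounds shown pair phenyl with fluoro only.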